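The compounds below may be only part of what the source reports. "The series", "measured", "known", "first", "only" and "open" are said of these compounds alone.

Compound 1, with the structure `COc1ccc(/C=C/C(=O)c2cc(OC)ccc2O)cc1`, is one of three compounds of a shared core measured in a physicochemical assay for lipophilicity; on this read-out higher numbers stand for higher lipophilicity and lower numbers for lower lipophilicity. Compound 1 gives 3.87, the highest of the three numbers. Compound 2, `COc1cccc(/C=C/C(=O)c2ccc(OC)cc2O)c1`, gives 3.86 in this assay, a number that lies within the scatter of compound 1, so the two cannot be told apart. Compound 3, `COc1cc(O)c(C(=O)/C=C/c2cc(OC)c(OC)c(OC)c2)cc1OC`, gives 3.5 in this assay, a number beyond the scatter below compound 1.

Compound 4, `COc1ccc(O)c(C(=O)/C=C/c2ccc(OC)c(OC)c2)c1`, has not yet been measured. It differs from compound 1 by methoxy in place of hydrogen on an aromatic carbon. No step between two measured compounds matches this change, so the expectation for compound 4 can rest only on the numbers shown. Compared with compound 1, more methoxy groups are carried by compound 3, which gives the lowest number of the three, 3.5, and this points toward a small downward move. The step from compound 1 to compound 4 is therefore expected to be small, a number 0.12 log units lower from compound 1 to compound 4 (within the scatter), and may not exceed the scatter. Compound 4 is estimated to give 3.75 in this assay, within a range from 3.45 to 4.05.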

Compound 4, partition coefficient: 3.52
Beside the measured number, compound 4's estimate is 0.23 log units above it; measured number inside the range.
By their numbers in this assay, from the lowest: compounds 3 and 4 (each within the scatter of the next); then compounds 2 and 1 (each within the scatter of the next).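

In this assay the exchange of hydrogen for methoxy on an aromatic carbon, ortho to a methoxy group and meta to a large group, gives a number 0.35 log units lower from compound 1 to compound 4 (beyond the scatter) and is a modest step. Within the data shown here, it is the only step here between compounds that differ in one place, and it shows that this single change at this position is enough to move the number beyond the scatter, something the earlier compounds could not show. Nothing at hand accounts for the size or direction of this step.

The compounds shown leave open whether methoxy would give a similar step elsewhere on the shared core. They also leave open what an amine, a carboxylic acid or a longer chain would give at this position in this assay.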